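The compounds below may be only part of what the source reports. "The series", "measured", "known", "first", "only" and "open" are said of these compounds alone.

Measured so far:
compound 1, `CN1C[C@@H](COc2ccc(C(=O)n3ccc4c(CC(=O)O)cccc43)cc2)Oc2ccccc21`: 2500 nM
compound 2, `CN1C[C@@H](COc2ccc(C(=O)Nc3cccc(CC(=O)O)c3)c(Cl)c2)Oc2ccccc21`: 2700 nM
compound 3, `Cc1cc(OC[C@@H]2CN(C)c3ccccc3O2)cc(C)c1C(=O)Nc1cccc(CC(=O)O)c1`: > 10000 nM

In an assay on CHO cells for displacement of a labelled ligand from prostacyclin receptor (Homo sapiens), read by scintillation counting, with a stated time of 30 min (on this read-out higher numbers stand for weaker inhibition and lower numbers for stronger inhibition), compound 2 gives 2700 nM, the higher of the two numbers read. Compound 1 gives 2500 nM, which lies within the usual scatter of compound 2, so no order between the two is claimed. Compound 3 returns a limit and not a number: the limit of > 10000 nM in this assay, at which 1 of the 3 values shown sits.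

The next member is compound 4, `Cc1ccc(CC(=O)O)cc1NC(=O)c1ccc(OC[C@@H]2CN(C)c3ccccc3O2)cc1Cl`. Against compound 2 the change is methyl in place of hydrogen on an aromatic carbon, the 3-(carboxymethyl)phenyl becoming 5-(carboxymethyl)-2-methylphenyl. Among the compounds with values here, no pair of measured compounds differs by this change alone, so nothing measured here sets its size. The expectation is a step in this assay of no more than the scatter, with no direction claimed beyond that; the step from compound 2 to compound 4 is estimated as a 1.2-fold lower number from compound 2 to compound 4 (0.09 log units; within the scatter). For compound 4 the estimate is 2200 nM, expected to fall between 600 nM and 8000 nM.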

Compound 4, inhibition constant: 1400 nM
The estimate for compound 4 lay 1.6-fold (0.20 log units) above the measured number, within the range that was stated.
By their numbers in this assay, from the lowest: compounds 4, 1 and 2 (each within the scatter of the next). At a limit, above all of these: compound 3.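

In this assay, within the data shown here, methyl in place of hydrogen on an aromatic carbon, ortho to a large group and para to a carboxymethyl group, gives a 1.9-fold lower number from compound 2 to compound 4 (0.29 log units; within the scatter), the first step that can be read. The 5-(carboxymethyl)-2-methylphenyl of compound 4 therefore stays within the scatter of the 3-(carboxymethyl)phenyl of compound 2, so this position carries a methyl without a step beyond the scatter. Nothing shown here bears on the cause of this step.

Open, as far as these compounds go, is whether methoxy, an amine or a longer alkyl chain at this position would give a step beyond the scatter. One pair also leaves open whether methyl at this position gives a similar step with the other parts of the molecule changed.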